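Working notes: compound 3 to compound 4

A few compounds are considered here, and "the series" means these few. Any claim that something is new, unique, unknown or untested is made for them only; others in the source may bear on it.

- compound 1 `CCc1[nH]c(C(C)=O)nc1[C@@H](O)[C@H](O)[C@H](O)CO` gives 1650 ng.h/mL
- compound 2 `OC[C@@H](O)[C@@H](O)[C@H](O)c1c[nH]c(C(F)(F)C(F)(F)F)n1` gives 3060 ng.h/mL
- compound 3 `Cc1nc(-c2nc([C@@H](O)[C@H](O)[C@H](O)CO)c[nH]2)cs1` gives 1970 ng.h/mL

All three values come from an ADME assay on the whole organism (plasma, strain 129/SvEvBrd x C57BL/6) for pharmacokinetics, with Mus musculus as the target, at a dose of 10 mg/kg by the oral route (on this read-out lower numbers stand for lower exposure and higher numbers for higher exposure at the dose given), and they sit close together. Compound 3 (1970 ng.h/mL) lies within the usual scatter of both compound 1 (1650 ng.h/mL) and compound 2 (3060 ng.h/mL). For the measured compounds named here, the measured compounds differ from one another in more than one place, so no single-change step is available to size the next move.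

The next compound is compound 4 `OC[C@@H](O)[C@@H](O)[C@H](O)c1c[nH]c(-c2cnccn2)n1` and the change from compound 3 is pyrazin-2-yl in place of 2-methyl-1,3-thiazol-4-yl on an aromatic carbon on an aromatic carbon of a five-membered aromatic ring with 2 nitrogen, between two ring nitrogen atoms. In words, pyrazin-2-yl stands in place of 2-methyl-1,3-thiazol-4-yl.

Going by the values given here, no measured compound falls outside the scatter around compound 3 (1970 ng.h/mL), so no step beyond the scatter is expected in this assay, in either direction. The expected step is small (a 1.0-fold higher number from compound 3 to compound 4 (0.01 log units; within the scatter)). The estimate for compound 4 is 2000 ng.h/mL with an expected range from 800 ng.h/mL to 4500 ng.h/mL and the measurement is still to come.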

Compound 4, area under the concentration-time curve: 1250 ng.h/mL
For compound 4 the middle estimate is 1.6-fold (0.20 log units) above the measured one; the measured number falls inside the stated range.
By their numbers in this assay, from the lowest: compounds 4, 1, 3 and 2 (each within the scatter of the next, the first and the last beyond it).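

In this assay, for the compounds shown here, pyrazin-2-yl in place of 2-methyl-1,3-thiazol-4-yl on the aromatic carbon between two ring nitrogen atoms gives a 1.6-fold lower number from compound 3 to compound 4 (0.20 log units; within the scatter), the first single-place step, so this swap of a five-membered for a six-membered aromatic ring does not move the read-out beyond the scatter. The wider span at this carbon appears only across the whole set: compound 4 gives 1250 ng.h/mL and compound 2, carrying pentafluoroethyl there, gives 3060 ng.h/mL, two values beyond the scatter of each other. No measurement at hand offers an explanation for either result.

Still open, going by these compounds, is how a carboxylic acid or an aminomethyl group on this same carbon would read in this assay. Also open, on these data alone, is whether the step from compound 3 to compound 4 would hold with a different group on the shared core.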